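Swapping the aryl group on a related core

The source may hold more compounds than are shown below. What is called first, only, known or untested is meant among the compounds shown, and "the series" means these compounds.

Compound 1 `COc1cc2c(cc1OC)C(c1cccc(N)c1)=NN=C(S)C2` and compound 2 `COc1cc2c(cc1OC)C(c1ccc(Cl)cc1)=NN=C(S)C2` share a core and differ in the group attached to it: 3-aminophenyl in place of 4-chlorophenyl on a carbon with a double bond to nitrogen. In a functional assay on the whole organism with Mus musculus as the target (a higher number here means that more compound is needed for the effect, a lower number that less compound is needed), compound 2 gives 82.4 umol/kg, while compound 1 gives 18.8 umol/kg, so the step of a 4.4-fold lower number from compound 2 to compound 1 (0.64 log units; beyond the scatter). Compound 3 `COc1cc2c(cc1OC)C(c1ccc(Cl)cc1)=NNC(=O)C2` carries the same 4-chlorophenyl group as compound 2 but on a different core; the difference between the two cores is not broken down here. In this assay compound 3 gives 102 umol/kg, which lies within the scatter of the value of compound 2 and is a larger number than that of compound 1.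

Compound 4 `COc1cc2c(cc1OC)C(c1cccc(N)c1)=NNC(=O)C2` is not yet measured. It relates to compound 3 as compound 1 relates to compound 2: 3-aminophenyl in place of 4-chlorophenyl on a carbon with a double bond to nitrogen. The place in compound 2 is additionally described as three ring bonds from the ring atom that bears a sulfanyl group, which compound 3 lacks, so this is the same kind of change rather than the same change. For the measured compounds named here, the expectation rests on the one measured example: because a 4.4-fold lower number from compound 2 to compound 1 (0.64 log units; beyond the scatter), a comparable step is estimated here, namely a 4.1-fold lower number from compound 3 to compound 4 (0.61 log units; beyond the scatter). Going by the values given here, since the cores differ and only one measured example exists, the range is kept wide. Compound 4 is expected to give about 25 umol/kg in this assay, estimated between 10 umol/kg and 65 umol/kg.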

Compound 4, dose for half-maximal effect: 19.3 umol/kg
For compound 4 the middle estimate is 1.3-fold (0.11 log units) above the measured one, within the range that was stated.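

On the second core the swap from 4-chlorophenyl to 3-aminophenyl gives a 5.3-fold lower number from compound 3 to compound 4 (0.72 log units; beyond the scatter), so less compound is again needed for the effect in this assay. Set beside the earlier step, the change carries over between these two cores in the same direction and at much the same size: the same change on two cores in this assay, a 4.4-fold lower number (0.64 log units; beyond the scatter) from compound 2 to compound 1 and a 5.3-fold lower number (0.72 log units; beyond the scatter) from compound 3 to compound 4, 1.2-fold (0.08 log units) apart, within the scatter of two such steps. For the compounds shown here, this is still only one change on two closely related cores in a test on the whole animal, so it sets no general rule for other cores, and it does not show what about the 3-aminophenyl group lowers the number or how the compounds produce their effect in the mouse.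

The compounds shown leave open whether the amine itself matters, which a plain phenyl group, a hydroxyl or an acetamide in its place could help to answer. They also leave open whether the step would hold on a core that differs further, for example one with ethoxy groups in place of the two methoxy groups.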